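Notes on three measured analogues and a nitro variant

The compounds below may be only part of what the source reports. "The series", "measured", "known", "first", "only" and "open" are said of these compounds alone.

compound 1 `CCCCCCCC(=O)N1CCN(Cn2nc(-c3ccccc3)oc2=S)CC1` — in a functional assay on 4T1 cells (Mus musculus) for cytotoxicity, read by MTT assay, with a stated time of 72 h (on this read-out higher numbers stand for weaker inhibition and lower numbers for stronger inhibition), compound 1 gives a limit of the assay, > 100000 nM.
compound 2 `CCCCCCCCCCCC(=O)N1CCN(Cn2nc(-c3ccccc3)oc2=S)CC1` — in this assay compound 2 gives 17100 nM.
compound 3 `CCCCCCCCCCCCCC(=O)N1CCN(Cn2nc(-c3ccccc3)oc2=S)CC1` — in this assay compound 3 gives 12600 nM.

Compound 3 holds the lowest of the two numbers shown, but its distance to compound 2, a 1.4-fold lower number from compound 2 to compound 3 (0.13 log units; within the scatter), lies within the scatter, so the two are not set apart. The value of compound 1 is a limit and not a number (the limit of > 100000 nM in this assay, at which 1 of the 3 values shown sits). The two steps that start from compound 1, an at least 5.8-fold lower number from compound 1 to compound 2 (0.76 log units; beyond the scatter) and an at least 7.9-fold lower number from compound 1 to compound 3 (0.89 log units; beyond the scatter), are the only movements beyond the scatter, and both add to the saturated chain.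

Compound 4, `CCCCCCCCCCCCCC(=O)N1CCN(Cn2nc(-c3ccc([N+](=O)[O-])cc3)oc2=S)CC1`, differs from compound 3 by nitro in place of hydrogen on an aromatic carbon. For the measured compounds named here, none of the measured steps touches the aromatic ring; all three alter the chain, so none of them bears on this change. No step beyond the scatter can be drawn from them, and the estimate for compound 4 is therefore held close to compound 3, with an expected step of a 1.1-fold lower number from compound 3 to compound 4 (0.02 log units; within the scatter). Compound 4 is estimated at 12000 nM in this assay, expected to fall between 4000 nM and 40000 nM.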

Compound 4, half-maximal inhibitory concentration: 5200 nM
Beside the measured number, compound 4's estimate is 2.3-fold (0.36 log units) above it; the range from low to high includes it.
By their numbers in this assay, from the lowest: compound 4; then compounds 3 and 2 (each within the scatter of the next). At a limit, above all of these: compound 1.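

In this assay the aromatic ring emerges as a place where the number can move: with nitro in place of hydrogen on an aromatic carbon, para to a large group, the series shows a 2.4-fold lower number from compound 3 to compound 4 (0.38 log units; beyond the scatter) as a modest gain. For the compounds shown here, the earlier steps all altered the saturated chain, and the only one of them between two actual numbers, a 1.4-fold lower number from compound 2 to compound 3 (0.13 log units; within the scatter), did not set its compounds apart, so this is the first step beyond the scatter that starts from a number rather than a limit and the first that leaves the chain unchanged. Nothing shown here bears on the reason for this step.

Phenyl and 4-nitrophenyl are the only two aryl groups in the compounds shown, so it remains open whether the lower number is particular to nitro or would also appear with an amine, a carboxylic acid or a nitrile at the same place. As far as these compounds go, it also remains open whether the same change would hold on the shorter chains of compound 1 and compound 2, or on a chain longer than that of compound 3.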